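The source may hold more compounds than are shown below. What is called first, only, known or untested is meant among the compounds shown, and "the series" means these compounds.

Measured in an ADME assay on the whole organism (Mus musculus, strain CD1) for pharmacokinetics, read by LC-MS, with a stated time of 24 h, at a dose of 5 mg/kg by the oral route; a higher number here means more compound in the circulation at the dose given, a lower number less compound in the circulation:
- compound 1 `O=C(O)Cn1nc(Cc2nc3cc(Cl)c(OCC(F)F)cc3[nH]2)c2ccccc2c1=O` gives 55 ng.h/mL
- compound 2 `C[C@H](C(=O)O)n1nc(Cn2cc3cc(OCC4CC4)c(Cl)cc3n2)c2ccccc2c1=O` gives 5510 ng.h/mL
- compound 3 `CC(C(=O)O)c1nn(Cc2cn3cc(OCC4CC4)c(C(F)(F)F)cc3n2)c2ccccc2c1=O` gives 4070 ng.h/mL

Compound 1 stands lowest of the three. Its value lies beyond the scatter below those of both other compounds, with compound 3 the nearer and compound 2 the further away.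

The next compound to be tested is compound 4 `O=C(O)Cn1nc(Cc2nc3cc(Cl)c(OCC4CC4)cc3[nH]2)c2ccccc2c1=O`. It keeps the core of compound 1 and changes one group: cyclopropyl takes the place of difluoromethyl on a saturated chain carbon bound to an oxygen on an aromatic ring, so that 2,2-difluoroethoxy becomes cyclopropylmethoxy (cyclopropyl in place of difluoromethyl on a saturated chain carbon bound to an oxygen on an aromatic ring).

Among the measured compounds shown here, no pair of measured compounds isolates this change, so the size of the step in this assay has to be judged indirectly. Cyclopropylmethoxy is carried by compound 2 at 5510 ng.h/mL and by compound 3 at 4070 ng.h/mL, which points upward. Both compounds also differ from compound 1 elsewhere, however, so they offer only weak guidance and their high values cannot be credited to this group. A small upward step, not far beyond the scatter, is therefore expected.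

The expected step is a 2.2-fold higher number from compound 1 to compound 4 (0.34 log units; beyond the scatter).

For compound 4 the estimated value is 120 ng.h/mL, with an expected range from 30 ng.h/mL to 500 ng.h/mL.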

Compound 4, area under the concentration-time curve: 72 ng.h/mL
Beside the measured number, compound 4's estimate is 1.7-fold (0.22 log units) above it; measured number inside the range.
By their numbers in this assay, from the lowest: compounds 1 and 4 (each within the scatter of the next); then compounds 3 and 2 (each within the scatter of the next).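

In this assay, the step at this place is a 1.3-fold higher number from compound 1 to compound 4 (0.12 log units; within the scatter), so putting cyclopropyl in place of difluoromethyl on a saturated chain carbon bound to an oxygen on an aromatic ring leaves the reading unmoved on the core of compound 1. Among the compounds shown here, this is the first direct reading of the change: until now, cyclopropylmethoxy could be seen only on compounds that also differ elsewhere, whereas here the exchange with 2,2-difluoroethoxy stands alone and the two groups cannot be told apart. Nothing offered here explains why the two groups read alike.

Still open, from the compounds shown here alone, is whether a different group at this place, such as a longer chain or an amine, would shift the number in this assay. Also open, going by these compounds, is which of the several places where compound 2 and compound 3 differ from compound 1 matters in this assay, and whether the exchange of difluoromethyl for cyclopropyl would read the same on another core.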